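This account rests on a few compounds, and the source may have more. Where it says the series, first, only, none or still open, it means among the compounds named here.

Working notes on the series. In a functional assay on MT4 cells (Homo sapiens) for cytotoxicity (a higher number here means a weaker inhibitor, a lower number a stronger inhibitor), compound 2 `N#Cc1c(N)cccc1Sc1ccc(Cl)cc1` gives 113000 nM. Compound 1 `Cc1ccc(Sc2cccc(N)c2C#N)cc1` reaches only a limit of this assay, > 200000 nM. The step of an at least 1.7-fold higher number from compound 2 to compound 1 (0.24 log units; that floor lies within the scatter) is therefore bounded, because of the limit of > 200000 nM in this assay, at which 1 of the 3 values shown sits. Compound 3 `N#Cc1c(N)cccc1Sc1cc(Cl)cc(Cl)c1` gives 3000 nM in this assay; the difference between the cores of compound 2 and compound 3 is not broken down here. Compound 4 `Cc1cc(Cl)cc(Sc2cccc(N)c2C#N)c1` is not yet measured; its change from compound 3 is methyl in place of chloro on an aromatic carbon, the same kind of change as methyl in place of chloro on an aromatic carbon, though here meta to a chloro group and meta to a large group rather than para to a large group. By analogy with compound 2 and its limit-bounded step to compound 1, a higher number is expected for compound 4, a step of about a 2.7-fold higher number from compound 3 to compound 4 (0.43 log units; beyond the scatter), giving an estimated 8000 nM.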

Compound 4, half-maximal inhibitory concentration: 16000 nM
Beside the measured number, compound 4's estimate is 2.0-fold (0.30 log units) below it, and the stated range covers the measured number.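

Methyl in place of chloro on the core of compound 3 gives a 5.3-fold higher number from compound 3 to compound 4 (0.73 log units; beyond the scatter) in this assay. On the other core, compound 1 gives > 200000 nM, which is a limit of the assay and not a number. One size for this change therefore cannot be carried from one core to the other, and neither a match nor a difference between the two cores is shown: the same change on two cores in this assay, an at least 1.7-fold higher number (0.24 log units; that floor lies within the scatter) from compound 2 to compound 1 and a 5.3-fold higher number (0.73 log units; beyond the scatter) from compound 3 to compound 4; the limit leaves it open whether they differ

Open, on these data alone, is how a fluoro group, a methoxy group or a trifluoromethyl group would read in place of the chloro group on either core. Also open, as far as these compounds go, is what methyl in place of the chloro group that remains in compound 4 would give.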